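The source may hold more compounds than are shown below. What is called first, only, known or untested is meant among the compounds shown, and "the series" means these compounds.

Compound 1 `O=c1cc(-n2cc(CNc3ccccc3)nn2)c2cc(Br)ccc2o1` in a functional assay on SW480 cells (Homo sapiens) for antiproliferative activity, read by MTT assay, with a stated time of 48 h (a lower number here means a stronger inhibitor, a higher number a weaker inhibitor), gives 18400 nM.
Compound 2 `Nc1ccc(OCc2cn(-c3cc(=O)oc4ccc(Br)cc34)nn2)cc1` in this assay gives 2090 nM.
Compound 3 `O=c1cc(-n2cc(COc3ccc(C(F)(F)F)cc3)nn2)c2cc(Br)ccc2o1` in this assay gives 3090 nM.

Among the three measured compounds, compound 3 stands second highest. Its nearest neighbour is compound 2, whose number lies within the scatter of it, while compound 1 lies further off, beyond the scatter. The two recorded steps frame this position: an 8.8-fold lower number from compound 1 to compound 2 (0.94 log units; beyond the scatter) was a modest change, and a 1.5-fold higher number from compound 2 to compound 3 (0.17 log units; within the scatter) stayed within the scatter.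

Compound 4 `O=c1cc(-n2cc(COc3ccc(F)cc3)nn2)c2cc(Br)ccc2o1` differs from compound 3 in one place: fluoro in place of trifluoromethyl on an aromatic carbon. The group that leaves and the group that enters both sit on an aromatic carbon of a six-membered aromatic ring of carbon only, para to a large group, and neither carries a hydrogen-bond donor or acceptor or a net charge.

Among the compounds with values here, only the step from compound 2 to compound 3 touches this same aromatic carbon, and that step, a 1.5-fold higher number from compound 2 to compound 3 (0.17 log units; within the scatter), stayed within the scatter even though amino gave way to trifluoromethyl. With fluoro now entering in place of trifluoromethyl, a change no larger than that one is expected, with no clear direction. Compound 4 is therefore estimated at 3000 nM, within a range of 1200 nM to 7500 nM, which means an expected step of a 1.0-fold lower number from compound 3 to compound 4 (0.01 log units; within the scatter).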

Compound 4, half-maximal inhibitory concentration: 1770 nM
Beside the measured number, compound 4's estimate is 1.7-fold (0.23 log units) above it; measured number inside the range.
By their numbers in this assay, from the lowest: compounds 4, 2 and 3 (each within the scatter of the next); then compound 1.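

At the aromatic carbon para to a large group, three different groups can now be compared in this assay: with fluoro entering, neither a 1.7-fold lower number from compound 3 to compound 4 (0.24 log units; within the scatter) nor a 1.2-fold lower number from compound 2 to compound 4 (0.07 log units; within the scatter) leaves the scatter, so amino, trifluoromethyl and fluoro are not told apart here, even though trifluoromethyl has 4 heavy atoms and fluoro has 1 heavy atom. The step that does stand out lies at the other end of the chain: a 10-fold lower number from compound 1 to compound 4 (1.02 log units; beyond the scatter) is large and beyond the scatter, and it adds a second case alongside an 8.8-fold lower number from compound 1 to compound 2 (0.94 log units; beyond the scatter) in which a substituted phenoxy in place of anilino gives a lower number. Nothing measured here explains why these steps differ in size, so the result remains a description of the numbers only.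

Each of these two steps changes both the atom joining the ring to the chain and the group on the ring, so the compounds shown cannot separate those two changes; plain phenoxy or 4-fluoroanilino on the same core would be needed to do so. Going by these compounds, it also remains open whether a group such as a carboxylic acid or a longer alkyl chain at the same aromatic carbon would stand apart from amino, trifluoromethyl and fluoro.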